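Nitro in place of ethoxy on the aryl-triazole arm

This account rests on a few compounds, and the source may have more. Where it says the series, first, only, none or still open, it means among the compounds named here.

Going by the values given here, compound 2 `CCOc1ccc(-n2nncc2CN2C(=O)C3(C(C#N)=C(N)Oc4c3c3nc5ccccc5nc3c3ccccc43)c3ccccc32)cc1` gives 25200 nM in a functional assay on A549 cells (Homo sapiens) for antiproliferative activity, read by MTT assay, with a stated time of 48 h (a higher number here means a weaker inhibitor, a lower number a stronger inhibitor), the only number in the set. Compound 1 `COc1ccc(-n2nncc2CN2C(=O)C3(C(C#N)=C(N)Oc4c3c3nc5ccccc5nc3c3ccccc43)c3ccccc32)cc1` shows only a limit in this assay, namely > 50000 nM. The step of an at least 1.9-fold lower number from compound 1 to compound 2 (0.29 log units; that floor lies within the scatter) carries methyl in place of hydrogen on a saturated chain carbon bound to an oxygen on an aromatic ring; its floor sits within the scatter and so offers little guidance. Compound 3 `N#CC1=C(N)Oc2c(c3nc4ccccc4nc3c3ccccc23)C12C(=O)N(Cc1cnnn1-c1ccc([N+](=O)[O-])cc1)c1ccccc12` differs by nitro in place of ethoxy on an aromatic carbon. Among the compounds with values here, no measured step covers this exchange. The estimate for compound 3 in this assay is 30000 nM, range 10000 nM to 100000 nM, and the expected step of a 1.2-fold higher number from compound 2 to compound 3 (0.08 log units; within the scatter) stays within the scatter.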

Compound 3, half-maximal inhibitory concentration: > 50000 nM
Compound 3 ended at the assay's limit (the forecaster's own chance of this, stated with the estimate: 40%); middle value at least 1.6-fold (0.22 log units) from the limit.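

The exchange of 4-ethoxyphenyl for 4-nitrophenyl gives an at least 1.9-fold higher number from compound 2 to compound 3 (0.29 log units; that floor lies within the scatter) in this assay. Nitro, like methoxy, therefore gives no number at this aromatic carbon, and the step between compound 1 and compound 3 cannot be read, as both values are limits. Ethoxy remains the only group here with a number, and the readings crowd against the ceiling of the assay: the limit of > 50000 nM in this assay, at which 2 of the 3 values shown sit.

Going by these compounds, it remains open whether an amine or a longer chain such as propoxy on this carbon would give a value clear of the limit. On these data alone, how far compound 1 and compound 3 lie past the limit also stays unknown.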